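Ring-carbon substituent series: from compound 3 to compound 4

The source may hold more compounds than are shown below. What is called first, only, known or untested is meant among the compounds shown, and "the series" means these compounds.

Notes on the shared core. Three compounds are measured in an assay on Sf9 cells for inhibition of serine/threonine-protein kinase 4 (Homo sapiens), read by luminescence and ADP-Glo, with a stated time of 1 h, in the presence of a further agent that is not named here; on this read-out lower numbers stand for stronger inhibition and higher numbers for weaker inhibition. Compound 1 `CN1CC(=O)N(C)c2cnc(Nc3ccc(S(N)(=O)=O)cc3)nc21` gives 495 nM. Compound 2 `CC1C(=O)N(C)c2cnc(Nc3ccc(S(N)(=O)=O)cc3)nc2N1C` gives 313 nM, and the step of a 1.6-fold lower number from compound 1 to compound 2 (0.20 log units; within the scatter) stays within the scatter. Compound 3 `CN1C(=O)C(c2cccc(F)c2)N(C)c2nc(Nc3ccc(S(N)(=O)=O)cc3)ncc21` gives 134 nM, the lowest of the three numbers, separated from both others by steps beyond the scatter: a 3.7-fold lower number from compound 1 to compound 3 (0.57 log units; beyond the scatter) and a 2.3-fold lower number from compound 2 to compound 3 (0.37 log units; beyond the scatter). Both of those steps concern a 3-fluorophenyl entering on a saturated ring carbon in place of hydrogen or methyl.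

Compound 4 `CN1C(=O)C(c2ccccc2F)N(C)c2nc(Nc3ccc(S(N)(=O)=O)cc3)ncc21` differs from compound 3 by 2-fluorophenyl in place of 3-fluorophenyl on a saturated ring carbon; the two have the same atoms, joined differently. For the measured compounds named here, none of the measured steps bears on this change directly. Going by the values given here, nothing measured here varies the fluorophenyl itself: the only aryl-bearing compound is compound 3, and the other two carry hydrogen or methyl at that carbon. The aryl substituent is retained in compound 4, so the expectation rests on compound 3 alone. For compound 4 the step of a 1.1-fold higher number from compound 3 to compound 4 (0.05 log units; within the scatter) is expected to stay within the scatter, in no particular direction. Among the compounds with values here, compound 4 is therefore estimated at 150 nM, with a range from 60 nM to 400 nM, the width reflecting that no measured pair tests this change.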

Compound 4, half-maximal inhibitory concentration: 75 nM
Compound 4: middle estimate off by 2.0-fold (0.30 log units), on the high side, and the stated range covers the measured number.
By their numbers in this assay, from the lowest: compounds 4 and 3 (each within the scatter of the next); then compounds 2 and 1 (each within the scatter of the next).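

Within this assay, the first pair that varies only the fluorine placement on the aryl group at this saturated ring carbon does not separate 2-fluorophenyl from 3-fluorophenyl (a 1.8-fold lower number from compound 3 to compound 4 (0.25 log units; within the scatter)), so the two isomers read as equivalent on this measurement. Compound 4 also gives a second aryl-bearing example that stands beyond the scatter from both non-aryl compounds (a 4.2-fold lower number from compound 2 to compound 4 (0.62 log units; beyond the scatter); a 6.6-fold lower number from compound 1 to compound 4 (0.82 log units; beyond the scatter)), so the gain seen with a fluorophenyl in place of methyl or hydrogen no longer rests on compound 3 alone. Nothing available explains why a fluorophenyl at this carbon gives lower numbers than methyl or hydrogen.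

Still open is whether the fluorine matters at all, since the unsubstituted phenyl, 4-fluorophenyl and a chlorophenyl do not appear among the compounds shown, and neither does any difluorophenyl. As far as these compounds go, it is also open whether the aromatic ring itself is needed at this carbon, which a cyclohexyl group, a benzyl group or a longer alkyl chain would test, and whether an amine or a carboxylic acid on the aryl group would be tolerated.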